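Swapping acetyl for dimethylamino on a pyrazole growth inhibitor

The source may hold more compounds than are shown below. What is called first, only, known or untested is meant among the compounds shown, and "the series" means these compounds.

Of the compounds shown here, three built on one shared core have been tested in a functional assay on SN12C cells (Homo sapiens) for inhibition, read by sulforhodamine B assay, with a stated time of 48 h; a lower number here means a stronger inhibitor of growth, a higher number a weaker inhibitor of growth. Compound 1 `COc1cc(C)cc(-c2c(-c3ccnc(-c4ccc(C(C)=O)cc4)c3)cnn2CC#N)c1` gives 4490 nM and stands highest of the three numbers. Compound 2 `COc1cc(C)cc(-c2nn(CC#N)cc2-c2ccnc(-c3ccc(N(C)C)cc3)c2)c1` gives 730 nM, the lowest of the set, while compound 3 `Cc1cc(O)cc(-c2nn(CC#N)cc2-c2ccnc(-c3ccc(N(C)C)cc3)c2)c1` gives 4280 nM, which lies within the scatter of compound 1. Among the measured compounds shown here, the one step measured between neighbours, a 5.9-fold higher number from compound 2 to compound 3 (0.77 log units; beyond the scatter), concerns the oxygen substituent on the other aryl ring and so does not bear directly on the change now considered.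

Compound 4 `COc1cc(C)cc(-c2c(-c3ccnc(-c4ccc(N(C)C)cc4)c3)cnn2CC#N)c1` differs from compound 1 in a single place: dimethylamino in place of acetyl on an aromatic carbon. For the measured compounds named here, no measured pair isolates this exchange. What the set does show comes from compound 2, which carries the same dimethylamino-bearing phenyl as compound 4 but a different arrangement of the two aryl groups around the core. In this assay compound 2 gives 730 nM, well beyond the scatter from compound 1. On that slender basis the expected step in this assay is a modest move toward a lower number, a 3.0-fold lower number from compound 1 to compound 4 (0.48 log units; beyond the scatter), with wide uncertainty. Compound 4 is therefore estimated at 1500 nM, within a range of 400 nM to 6000 nM.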

Compound 4, concentration for 50% growth inhibition: 398 nM
Estimate against measurement, compound 4: 3.8-fold (0.58 log units) above; measured number outside the range, below it.
By their numbers in this assay, from the lowest: compounds 4 and 2 (each within the scatter of the next); then compounds 3 and 1 (each within the scatter of the next).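

In this assay, among the compounds shown here, the exchange of acetyl for dimethylamino gives an 11-fold lower number from compound 1 to compound 4 (1.05 log units; beyond the scatter) and so provides the first direct reading of this change, which is large and beyond the scatter. With the rest of compound 1 left as it is, the group on this aromatic carbon, para to a large group, therefore has a strong bearing on the growth-inhibition read-out, even though the two groups match in heavy-atom count, with one hydrogen-bond acceptor each and no net charge. Nothing measured here explains why the two groups differ so much in this assay.

Whether dimethylamino is a particular requirement at this place stays open, as the compounds shown include no other group there, such as a primary amine, a carboxylic acid or a longer chain. It is also open whether the exchange would have a similar size with the arrangement of the two aryl groups seen in compound 2, for which the compounds shown offer no acetyl partner.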